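The compounds below may be only part of what the source reports. "The series", "measured", "known", "first", "only" and "open" are said of these compounds alone.

Measured so far:

compound 1 `CCc1c(Cc2c(Cl)cccc2Cl)nc(SCC(=O)c2ccc(F)cc2)[nH]c1=O`: > 55000 nM
compound 2 `CCc1c(Cc2c(Cl)cccc2Cl)nc(SCC(=O)c2ccc(OC)cc2)[nH]c1=O`: > 54000 nM
compound 3 `CC(C)c1c(Cc2c(F)cccc2Cl)nc(SCC(=O)c2ccc(F)cc2)[nH]c1=O`: > 56000 nM

All three were tested in an ADME assay on MT4 cells (Homo sapiens) for cytotoxicity, read by MTT assay; a lower number here means that less compound is tolerated, a higher number that more compound is tolerated. For compound 1 the result is only a limit of the assay, > 55000 nM. For compound 2 the result is likewise a limit, > 54000 nM. For compound 3 the result is again a limit, > 56000 nM.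

Compound 1 and compound 2 share one core and differ in a single place, (methoxy in place of fluoro on an aromatic carbon). The step that the two limits leave unreadable from compound 1 to compound 2 cannot be read, because compound 1 sits at the limit of > 55000 nM in this assay, at which 1 of the 3 values shown sits, and compound 2 sits at the limit of > 54000 nM in this assay, at which 1 of the 3 values shown sits: both results are limits, so no size can be taken from them.

Compound 4 `COc1ccc(C(=O)CSc2nc(Cc3c(F)cccc3Cl)c(C(C)C)c(=O)[nH]2)cc1` is not yet measured. Among the measured compounds shown here, it differs from compound 3 by methoxy in place of fluoro on an aromatic carbon, the same change as the one from compound 1 to compound 2, made in the same place. How the core of compound 3 differs from the core of compound 1 is not broken down here.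

For compound 4 the step that the limit leaves unreadable from compound 3 to compound 4 is expected to be small, resting on the earlier pair, where compound 1 and compound 2 both reach a limit and nothing points to a change in tolerance, and on compound 3 sitting at the limit of > 56000 nM in this assay, at which 1 of the 3 values shown sits. Compound 4 is therefore estimated at 80000 nM, most likely reported again only as a limit, within 40000 nM to 200000 nM.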

Compound 4, half-maximal cytotoxic concentration: > 11000 nM
Compound 4: no number, only a limit; the forecaster's own chance of this, stated with the estimate: 85%; the middle value is on the limit's open side.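

In this assay compound 4 gives > 11000 nM and this is a limit of the assay, not a number. Compound 3 also has only a limit, and no size can be read for the step between compound 3 and compound 4. The compounds shown leave open how much of each compound the cells tolerate, and whether methoxy in place of fluoro changes that tolerance at all.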